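Taking one methoxy group from compound 2

The source may report more compounds than this note shows. Statements on the series, on what has been measured and on what is new or still open speak of the compounds shown alone.

Two compounds have been measured so far in a functional assay on HT-29 cells (Homo sapiens) for antiproliferative activity, read by sulforhodamine B assay, with a stated time of 48 h (on this read-out higher numbers stand for weaker inhibition and lower numbers for stronger inhibition), and are shown here:

- compound 1 `COc1ccc(OS(=O)(=O)c2ccc(N3CCN(C)C3=O)cc2)cc1` gives > 100000 nM as a limit of the assay
- compound 2 `CCN1CCN(c2ccc(S(=O)(=O)Oc3ccc(OC)c(OC)c3)cc2)C1=O` gives 37000 nM as a measured number

The entry for compound 1 is a limit and not a number. Among the compounds with values here, compound 2 therefore holds the only number in the set, and no second number exists to rank it against.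

The next compound, compound 3 `CCN1CCN(c2ccc(S(=O)(=O)Oc3ccc(OC)cc3)cc2)C1=O`, has not yet been measured. It differs from compound 2 in one place: hydrogen in place of methoxy on an aromatic carbon, ortho to a methoxy group and meta to a large group.

Within the data shown here, no step between measured compounds is available to size this change. The expectation therefore rests on compound 2 at 37000 nM as the sole anchor, and it is for a modest move toward weaker inhibition. The expected size of a 1.9-fold higher number from compound 2 to compound 3 (0.28 log units; within the scatter) is small, near the edge of the usual scatter. For compound 3 the estimated value is 70000 nM, with an expected range from 25000 nM to 150000 nM in this measurement.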

Compound 3, half-maximal inhibitory concentration: 60000 nM
Compound 3: the middle estimate sits 1.2-fold (0.07 log units) above what was measured, and the stated range covers the measured number.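

Hydrogen in place of methoxy on an aromatic carbon, ortho to a methoxy group and meta to a large group, gives a 1.6-fold higher number from compound 2 to compound 3 (0.21 log units; within the scatter) in this assay, so this first measured step at the position does not separate compound 3 from compound 2 beyond the usual scatter, and compound 3 still gives a measured number with only one methoxy group left on that ring. Methyl in place of hydrogen on a saturated chain carbon bound to an amide-type nitrogen in a ring gives an at least 1.6-fold lower number from compound 1 to compound 3 (0.22 log units; that floor lies within the scatter), which is only a floor and so sets no true size for this step. Compound 1 stands at a limit and not a number, and this bounds all that can be read from that step: the limit of > 100000 nM in this assay, at which 1 of the 3 values shown sits.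

The compounds shown leave open whether a hydroxyl group or an amine at the position of the removed methoxy group would give a step beyond the scatter. They also leave open what a longer chain on the amide-type nitrogen would give, and whether any such compound would reach a clearly lower number in this assay.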